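The compounds below may be only part of what the source reports. "The series", "measured", "known", "first", "only" and "open" are said of these compounds alone.

Of the compounds shown here, two have so far been measured in a functional assay on the whole organism (strain STD-dd) with Mus musculus as the target, in the maximal electroshock model, with a stated time of 2 h; a higher number here means that more compound is needed for the effect, a lower number that less compound is needed. Compound 1 `CNS(=O)(=O)Cc1noc2ccccc12` gives 23 mg/kg, and compound 2 `NS(=O)(=O)Cc1noc2ccc(F)cc12` gives 15 mg/kg. Compound 2 holds the lowest of the two numbers; its nearest neighbour is compound 1, whose number sits higher by an amount that lies within the usual scatter of this assay . Compound 3 `CNS(=O)(=O)Cc1noc2ccc(F)cc12` has not yet been measured in this assay . It differs from compound 2 in one place: methyl in place of hydrogen on a sulfonamide nitrogen. For the measured compounds named here, no measured pair shows this change on its own, so its size cannot be read from the data. Compound 1 carries the same methyl on its sulfonamide nitrogen and gives 23 mg/kg in this assay , a number close to that of compound 2. The step from compound 2 to compound 3 is expected to be small, a 1.2-fold higher number from compound 2 to compound 3 (0.08 log units; within the scatter), not beyond the scatter in either direction. Compound 3 is estimated to give 18 mg/kg in this assay , with a range from 9 mg/kg to 36 mg/kg.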

Compound 3, dose for half-maximal effect: 35 mg/kg
Compound 3: the middle estimate sits 1.9-fold (0.29 log units) below what was measured; low and high end bracket the measured number.
By their numbers in this assay, from the lowest: compounds 2, 1 and 3 (each within the scatter of the next, the first and the last beyond it).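

For the compounds shown here, the methyl on the sulfonamide nitrogen now has a size of its own in this assay: the change gives a 2.3-fold higher number from compound 2 to compound 3 (0.37 log units; beyond the scatter), a modest step and the first reading of this change alone. Fluoro in place of hydrogen on an aromatic carbon, with the methyl kept on the nitrogen, gives a 1.5-fold higher number from compound 1 to compound 3 (0.18 log units; within the scatter), so this one pair does not separate that change from the usual scatter. Nothing at hand offers a reason for either step.

The compounds shown leave open whether the methyl step holds on the core without the fluoro. They also leave open how a longer chain such as ethyl or propyl on the sulfonamide nitrogen, or a chloro in place of the fluoro, would read.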